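Working notes: from compound 1 to compound 4

This account rests on a few compounds, and the source may have more. Where it says the series, first, only, none or still open, it means among the compounds named here.

Of the compounds shown here, three have been read in a functional assay on WHCO1 cells (Homo sapiens) for antiproliferative activity, read by MTT assay, with a stated time of 48 h; on this read-out higher numbers stand for weaker inhibition and lower numbers for stronger inhibition. Compound 1 `C=CCSSC=CC[S+]([O-])Cc1ccc(OC)cc1` gives 7400 nM, the lower of the two numerical values and so the stronger inhibition of that pair. Compound 2 `C=CCSS/C=C/C[S+]([O-])CCC` gives 37000 nM, a number higher than that of compound 1 by a margin beyond the usual scatter. Compound 3 `COc1ccc(CSC=CCSCc2ccc(OC)cc2)cc1` returns only a limit of the assay, > 200000 nM, and not a number.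

Compound 4 `COc1ccc(C[S+]([O-])CC=CSSCc2ccccc2)cc1` departs from compound 1 at one place: phenyl in place of vinyl on a saturated chain carbon bound to a sulfur. The change sits on a saturated chain carbon bound to a sulfur, and cut one bond further out it reads allyl to benzyl. Among the measured compounds shown here, the series holds no measured step of this kind, so the change cannot be sized directly from the data. The expectation therefore rests on compound 1 at 7400 nM, whose remaining structure compound 4 keeps, and no step beyond the scatter is expected in this assay. The estimated step of a 1.1-fold lower number from compound 1 to compound 4 (0.06 log units; within the scatter) is expected to be small. Compound 4 is expected at 6500 nM, with an estimated range of 2500 nM to 17000 nM.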

Compound 4, half-maximal inhibitory concentration: 3100 nM
Compound 4: middle estimate off by 2.1-fold (0.32 log units), on the high side, and the stated range covers the measured number.
By their numbers in this assay, from the lowest: compound 4; then compound 1; then compound 2. At a limit, above all of these: compound 3.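

In this assay the series now holds its first measured step at this place, on a saturated chain carbon bound to a sulfur: phenyl in place of vinyl, which reads allyl to benzyl when cut one bond further out, gives a 2.4-fold lower number from compound 1 to compound 4 (0.38 log units; beyond the scatter). The place therefore accepts a six-membered aromatic ring of carbon only where a vinyl stood, with the number moving down and not up, and compound 4 holds the lowest of the numerical values shown, though this rests on a single pair. Nothing shown gives a cause for this modest step.

One pair cannot separate an effect of the aromatic ring itself from an effect of the extra heavy atoms that enter with it, so a saturated cyclohexylmethyl group or a longer chain such as phenethyl at the same place would be needed to tell the two apart. From the compounds shown here alone, it also remains open whether the step holds for a benzyl carrying an amine or a carboxylic acid on its ring.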